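Removing the Nitrile from the Biaryl Urea Series

A few compounds are considered here, and "the series" means these few. Any claim that something is new, unique, unknown or untested is made for them only; others in the source may bear on it.

Measured compounds:
- Compound 1, `Cc1ccc(CN2CCC(NC(=O)NCc3ccc(-c4cccc(C#N)c4)cc3)CC2)cc1`, gives 6.39 in an in vitro functional assay on HEK293 cells for antagonist activity at melanin-concentrating hormone receptor 1 (Homo sapiens), read by GTPgammaS binding, with a stated time of 45 min; a lower number here means a less potent compound, a higher number a more potent compound, by a factor of ten per unit of this negative logarithm.
- Compound 2, `Cc1ccc(CN2CCC(NC(=O)NCc3ccc(-c4ccccc4)cc3)CC2)cc1`, gives 5.98 in this assay.
- Compound 3, `Cc1ccc(CN2CCC(CCN(Cc3ccc(-c4cccc(C#N)c4)cc3)C(=O)NC(C)(C)CO)CC2)cc1`, gives 7.08 in this assay.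

Compound 3 stands highest of the three, with the nearest measured value being that of compound 1. How the core of compound 3 differs from that of compound 1 is not broken down here. Between compound 1 and compound 2 the change is hydrogen in place of cyano on an aromatic carbon, and it moved the value by a number 0.41 log units lower from compound 1 to compound 2 (beyond the scatter).

Compound 4, `Cc1ccc(CN2CCC(CCN(Cc3ccc(-c4ccccc4)cc3)C(=O)NC(C)(C)CO)CC2)cc1`, has not yet been measured. It is related to compound 3 by hydrogen in place of cyano on an aromatic carbon, the same kind of change as that between compound 1 and compound 2, made at the same kind of place. Since the earlier step was a number 0.41 log units lower from compound 1 to compound 2 (beyond the scatter), compound 4 is expected to fall by a number 0.41 log units lower from compound 3 to compound 4 (beyond the scatter) in this assay, a step of about the same size, with a single precedent as its only support. The estimate for compound 4 is therefore 6.67, with a range from 6.2 to 7.1.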

Compound 4, negative logarithm of the antagonist equilibrium constant: 6.2
Estimate against measurement, compound 4: 0.47 log units above; measured number inside the range.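

Replacing the 3-cyanophenyl group with phenyl on the core of compound 3 again lowered the value in this assay, a number 0.88 log units lower from compound 3 to compound 4 (beyond the scatter). The direction of the change therefore carried over from one core to the other, but its size did not: the same change on two cores in this assay, a number 0.41 log units lower (beyond the scatter) from compound 1 to compound 2 and a number 0.88 log units lower (beyond the scatter) from compound 3 to compound 4, 0.47 log units apart, beyond the scatter of two such steps. These two pairs show that on both cores the compound with the nitrile gives the higher value, but they do not explain why the step differs in size or provide a size that could be assumed for a further core in this series.

The compounds shown leave open how an amide, a fluorine or a methoxy group at this position would compare with the nitrile on either core. They also leave open which of the structural differences between the core of compound 1 and the core of compound 3, such as the hydroxyl-bearing chain on the urea, goes with the larger step.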